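The source may report more compounds than this note shows. Statements on the series, on what has been measured and on what is new or still open speak of the compounds shown alone.

Three compounds built on one shared core have been examined in a functional assay on the whole organism for inhibition, with Chenopodium ficifolium as the target, with a stated time of 72 h, tested at 10 mg/L; on this read-out lower numbers stand for less inhibition of growth and higher numbers for more inhibition of growth at the one concentration tested. Compound 1 `COc1cc(C)nc2n/c(=N/C(=O)c3c(-c4ccc(Cl)cc4Cl)noc3C)sn12` gives 45.7%. Compound 2 `Cc1onc(-c2ccc(Cl)cc2Cl)c1C(=O)/N=c1/nc2nc(Cl)cc(C)n2s1` gives 18.6%. Compound 3 `COc1cc(OC)n2s/c(=N\C(=O)c3c(-c4ccc(Cl)cc4Cl)noc3C)nc2n1` gives 28.9%. On these numbers compound 3 stands second highest of the three: compound 1 lies above it and compound 2 below it, and both gaps are beyond the scatter. Among the measured compounds shown here, the one measured step that alters a single place runs a number 16.8 percentage points lower from compound 1 to compound 3 (beyond the scatter), a methoxy entering in place of a methyl on an aromatic carbon.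

Compound 4 `COc1cc(Cl)nc2n/c(=N/C(=O)c3c(-c4ccc(Cl)cc4Cl)noc3C)sn12` is the compound that follows, and it differs from compound 3 in that (chloro in place of methoxy on an aromatic carbon). For the measured compounds named here, no measured step swaps a chloro for a methoxy, so nothing among the measured steps bears on this change directly. Going by the values given here, what the numbers do show is that compound 2, the one measured compound carrying a chloro on the core, gives the lowest of the three values, and that compound 3 already sits well under compound 1. The step expected in this assay is a number 4.9 percentage points lower from compound 3 to compound 4 (within the scatter), a modest fall rather than a rise. Compound 4 is accordingly estimated at 24%, with a range from 8% to 42%.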

Compound 4, percent growth inhibition at one concentration: 19.3%
Compound 4: the middle estimate sits 4.7 percentage points above what was measured; low and high end bracket the measured number.
By their numbers in this assay, from the lowest: compounds 2, 4 and 3 (each within the scatter of the next, the first and the last beyond it); then compound 1.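

With the rest of the molecule unchanged, chloro in place of methoxy at this position in this assay gives a number 9.6 percentage points lower from compound 3 to compound 4 (within the scatter), so the two groups cannot be told apart here, whereas chloro in place of methyl gives a number 26.4 percentage points lower from compound 1 to compound 4 (beyond the scatter). Of the three groups compared at this position, only the methyl of compound 1 stands clear of both others. Methoxy in place of methyl on an aromatic carbon now has a second reading, a number 0.7 percentage points higher from compound 2 to compound 4 (within the scatter), and it does not repeat the first: the same change on two cores in this assay, a number 16.8 percentage points lower (beyond the scatter) from compound 1 to compound 3 and a number 0.7 percentage points higher (within the scatter) from compound 2 to compound 4, 17.5 percentage points apart, beyond the scatter of two such steps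

From the compounds shown here alone, whether an amine or an ethoxy at this position would read with compound 1 or with compound 4 stays open, and so does whether a group exists there that goes beyond the methyl. Going by these compounds, it is also open which of the two readings of the methoxy for methyl change would hold on a further core, and how any of these steps would look at a concentration other than the single one used in this assay.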